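From Methylsulfanyl to Methylsulfonyl in a Small Inhibitor Set

The source may report more compounds than this note shows. Statements on the series, on what has been measured and on what is new or still open speak of the compounds shown alone.

Among the measured compounds shown here, compound 2 (`CSc1ccc(CSc2nc(-c3ccc(Br)cc3)c(-c3ccncc3)[nH]2)cc1`) gives 2400 nM in a functional assay (Homo sapiens) for inhibition (on this read-out lower numbers stand for stronger inhibition and higher numbers for weaker inhibition), and so holds the higher of the two numbers so far. Compound 1 (`CS(=O)(=O)c1ccc(CSc2nc(-c3ccc(Cl)cc3)c(-c3ccncc3)[nH]2)cc1`) gives 320 nM in this assay and is the stronger inhibitor of the two, with a gap beyond the usual scatter. Compound 3 (`CS(=O)(=O)c1ccc(CSc2nc(-c3ccc(Br)cc3)c(-c3ccncc3)[nH]2)cc1`) is still unmeasured and differs from compound 2 by one change (methylsulfonyl in place of methylsulfanyl on an aromatic carbon), methylsulfonyl in place of methylsulfanyl on an aromatic carbon. For the measured compounds named here, no measured pair shows this change alone, as compound 1 and compound 2 differ in more than one place. Compound 1 does carry methylsulfonyl, however, and its 320 nM leads to the expectation of a clearly lower number in this assay for the new compound. The expected move is a 6.0-fold lower number from compound 2 to compound 3 (0.78 log units; beyond the scatter) and would lie beyond the scatter. The estimated value for compound 3 is 400 nM (range 130 nM to 1200 nM).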

Compound 3, half-maximal inhibitory concentration: 640 nM
Compound 3: middle estimate off by 1.6-fold (0.20 log units), on the low side, within the range that was stated.
By their numbers in this assay, from the lowest: compounds 1 and 3 (each within the scatter of the next); then compound 2.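

Among the compounds shown here, compound 2 and compound 3 isolate this change for the first time: in this assay, 4-(methylsulfonyl)phenyl in place of 4-(methylsulfanyl)phenyl gives (a 3.8-fold lower number from compound 2 to compound 3 (0.57 log units; beyond the scatter)), a modest step showing that the read-out responds to the group at this position. Bromo in place of chloro on an aromatic carbon can also now be read alone, and it gives (a 2.0-fold higher number from compound 1 to compound 3 (0.30 log units; within the scatter)), so compound 1 and compound 3 cannot be told apart on this read-out. The data on hand offer no explanation for the methylsulfonyl step.

The compounds shown leave open how a sulfonamide, a carboxylic acid or an amine at this position would compare with methylsulfonyl. From the compounds shown here alone, how a fluoro or a methoxy group would read in place of bromo or chloro also remains open.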